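Isopropyl in place of propyl: from compound 3 to compound 4

A few compounds are considered here, and "the series" means these few. Any claim that something is new, unique, unknown or untested is made for them only; others in the source may bear on it.

The measured compounds and their values:
compound 1 `CCCc1nc(C)c2c(C(C)C)nnc(S)n12`: in a functional assay for inhibition, with Homo sapiens as the target (a lower number here means a stronger inhibitor, a higher number a weaker inhibitor), compound 1 gives > 48000 nM, which is a limit of the assay and not a number.
compound 2 `CCCc1nc(C)c2cnnc(SC)n12`: in this assay compound 2 gives > 48000 nM, again only a limit.
compound 3 `CCCc1nnc(SC)n2c(CCC)nc(C)c12`: in this assay compound 3 gives > 48000 nM, again only a limit.

Among the compounds with values here, all three values sit at the same limit (the limit of > 48000 nM in this assay, at which 3 of the 3 values shown sit), so no compound can be placed above or below another. Within the data shown here, the single one-place step among them, a step that the two limits leave unreadable from compound 2 to compound 3, is unreadable, because both ends sit at the limit (the limit of > 48000 nM in this assay, at which 3 of the 3 values shown sit). Compound 3 therefore stands only at a limit, with no number of its own.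

Compound 4 `CCCc1nc(C)c2c(C(C)C)nnc(SC)n12` differs from compound 3 by isopropyl in place of propyl on an aromatic carbon. Among the measured compounds shown here, no measured step bears on this change: the only step recorded, from compound 2 to compound 3, gives no readable size. Compound 1, which itself carries an isopropyl, gives only a limit in this assay. Nothing measured therefore points to any step beyond the scatter, and it is expected that compound 4 will also sit at the limit in this assay, so the step that the limit leaves unreadable from compound 3 to compound 4 is an estimate only. For compound 4 the estimate is 70000 nM, with a range from 20000 nM to 250000 nM.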

Compound 4, half-maximal inhibitory concentration: > 48000 nM
Compound 4 was reported as a limit (the forecaster's own chance of this, stated with the estimate: 85%); the middle value lies beyond the limit too.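

No step from compound 1, compound 2 or compound 3 to compound 4 can be read in this assay, because both ends of each step sit at a limit: the limit of > 48000 nM in this assay, at which 4 of the 4 values shown sit.

The compounds shown leave open whether any change to the shared core would give a measurable number in this assay, and how these four compounds rank against one another.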